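A few compounds are considered here, and "the series" means these few. Any claim that something is new, unique, unknown or untested is made for them only; others in the source may bear on it.

For the measured compounds named here, in a functional assay on HepG2 cells (Homo sapiens) for antiproliferative activity, read by MTT assay, with a stated time of 72 h (a lower number here means a stronger inhibitor, a higher number a weaker inhibitor), the series so far shows no measurable potency at all. Compound 1 `O=C1O/C(=C\Cn2cc(-c3cc(F)cc(F)c3)nn2)C(OCc2ccccc2)=C1OCc1ccccc1` returns only a limit of the assay, > 100000 nM. Compound 3 `COc1ccccc1-c1cn(C/C=C2\OC(=O)C(OCc3ccccc3)=C2OCc2ccccc2)nn1` likewise returns only a limit, > 100000 nM. Going by the values given here, the single measured step, a step that the two limits leave unreadable from compound 1 to compound 3, is therefore unreadable, because both of its ends sit at the limit of > 100000 nM in this assay, at which 3 of the 3 values shown sit.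

Compound 2 `COc1ccccc1-c1cn(C[C@H](O)[C@H]2OC(=O)C(OCc3ccccc3)=C2OCc2ccccc2)nn1` stands at the same place: in this assay compound 2 gives only a limit, > 100000 nM. Every value recorded in the set is such a limit, so compound 2 can be placed neither above nor below its neighbours.

Compound 4 `COc1ccc(-c2cn(C[C@H](O)[C@H]3OC(=O)C(OCc4ccccc4)=C3OCc3ccccc3)nn2)cc1` differs from compound 2 by 4-methoxyphenyl in place of 2-methoxyphenyl on an aromatic carbon. Among the compounds with values here, no measured step bears on this change, and the one step that exists gives no readable size. With nothing to suggest a move out of the limit region, compound 4 is expected to stay there, and the step from compound 2 to compound 4 is estimated as a step that the limit leaves unreadable from compound 2 to compound 4. Compound 4 is thus expected to give about 150000 nM in this assay, in a range from 50000 nM to 500000 nM, most likely again reported as a limit.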

Compound 4, half-maximal inhibitory concentration: 46400 nM
The estimate for compound 4 lay 3.2-fold (0.51 log units) above the measured number, and the stated range ends above it.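

In this assay, 4-methoxyphenyl in place of 2-methoxyphenyl, on an aromatic carbon of the five-membered aromatic ring with 3 nitrogen, gives an at least 2.1-fold lower number from compound 2 to compound 4 (0.33 log units; beyond the scatter). For the compounds shown here, this is the first readable step, and it comes from a change that keeps the same atoms and only joins them differently, so this place on the core can respond to where the methoxy group stands on the phenyl ring. Compound 4 is the only compound shown that leaves the limit of the assay: the limit of > 100000 nM in this assay, at which 3 of the 4 values shown sit.

As far as these compounds go, compound 2 gives only a limit, so the full size of the step stays open, and the step between compound 1 and compound 3 remains unreadable. Also open, from the compounds shown here alone, are whether the same change would register on the core of compound 3, and how an amine or a carboxylic acid in place of the methoxy group would read.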